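Working notes on a small amine-ring series, one compound pending

The compounds below may be only part of what the source reports. "The series", "measured", "known", "first", "only" and "open" are said of these compounds alone.

Measured in a functional assay on A549 cells (Homo sapiens) for antiproliferative activity, read by MTT assay, with a stated time of 72 h; on this read-out higher numbers stand for weaker inhibition and lower numbers for stronger inhibition:
compound 1, `COc1cc2ncnc(Nc3cccc(I)c3)c2cc1OCCCN1CCNCCNCCNCC1`: 14500 nM
compound 2, `COc1cc2ncnc(Nc3ccc(Cl)cc3Cl)c2cc1OCCCN1CCNCCNCCNCC1`: 23800 nM
compound 3, `COc1cc2ncnc(Nc3cccc(I)c3)c2cc1OCCCN1CCNCCNCC1`: 26200 nM

Compound 4, `COc1cc2ncnc(Nc3ccc(Cl)cc3Cl)c2cc1OCCCN1CCNCCNCC1`, is not yet measured in this assay.

Two changes run through the set. Compound 3 differs from compound 1 in its core: a group of 9 heavy atoms (6 carbon, 3 nitrogen; one nine-membered non-aromatic ring with 3 hetero atoms) in place of a group of 12 heavy atoms (8 carbon, 4 nitrogen; one twelve-membered non-aromatic ring with 4 hetero atoms), on a saturated chain carbon, three bonds along the chain from an oxygen on an aromatic ring. This gives a 1.8-fold higher number from compound 1 to compound 3 (0.26 log units; within the scatter). Compound 2 differs from compound 1 in the aryl group on the shared core: 2,4-dichlorophenyl in place of 3-iodophenyl on a nitrogen on an aromatic ring. This gives a 1.6-fold higher number from compound 1 to compound 2 (0.22 log units; within the scatter). For the measured compounds named here, no step is worked out between compound 2 and compound 3; their two numbers lie close to each other, and all three measured compounds sit within the usual scatter of one another, so no order among them can be read from these data.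

Compound 4 carries the same change relative to compound 3 that compound 2 carries relative to compound 1: 2,4-dichlorophenyl in place of 3-iodophenyl on a nitrogen on an aromatic ring. The place of the change is described in the same words in both pairs, so it is the same change, made on the core of compound 3 instead of the core of compound 1. The step expected from compound 3 to compound 4 in this assay is a 1.5-fold higher number from compound 3 to compound 4 (0.18 log units; within the scatter), set beside a 1.6-fold higher number from compound 1 to compound 2 (0.22 log units; within the scatter), on which it rests, with the added uncertainty that the change has been seen only once. Compound 4 is therefore estimated at 40000 nM, with a likely range from 15000 nM to 100000 nM.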

Compound 4, half-maximal inhibitory concentration: 44200 nM
Estimate against measurement, compound 4: 1.1-fold (0.04 log units) below, and the stated range covers the measured number.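

In this assay, placing 2,4-dichlorophenyl where 3-iodophenyl stood on the core of compound 3 gives a 1.7-fold higher number from compound 3 to compound 4 (0.23 log units; within the scatter), and this step agrees with the same change on the core of compound 1: the same change on two cores in this assay, a 1.6-fold higher number (0.22 log units; within the scatter) from compound 1 to compound 2 and a 1.7-fold higher number (0.23 log units; within the scatter) from compound 3 to compound 4, 1.0-fold (0.01 log units) apart, within the scatter of two such steps. The ring change reads the same way, with the smaller ring in place of the larger ring giving a 1.9-fold higher number from compound 2 to compound 4 (0.27 log units; within the scatter) on the 2,4-dichlorophenyl side, in agreement with the step on the 3-iodophenyl side: the same change on two cores in this assay, a 1.8-fold higher number (0.26 log units; within the scatter) from compound 1 to compound 3 and a 1.9-fold higher number (0.27 log units; within the scatter) from compound 2 to compound 4, 1.0-fold (0.01 log units) apart, within the scatter of two such steps. Across these four compounds, each change therefore carries from one core to the other with no visible difference, but every step lies within the scatter, so this is agreement between steps too small to tell from repeat variation, and it establishes neither a real effect of either change nor that the changes would combine in the same way elsewhere in the series.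

The compounds shown leave open whether such transfer would hold for a change large enough to stand clear of the scatter, for instance with a plain phenyl group on the aromatic nitrogen. They also leave open what a longer chain to the ring, or an open-chain amine in place of the ring, would do in this assay.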